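The source may report more compounds than this note shows. Statements on the series, on what has been measured and on what is new or still open speak of the compounds shown alone.

compound 1 `Oc1cccc(-c2cc(-c3ccccc3)cc(-c3ccccc3)n2)c1`: 9950 nM
compound 2 `Oc1cccc(-c2cc(-c3ccccc3)cc(-c3ccsc3)n2)c1`: 7660 nM
compound 3 `Oc1cccc(-c2cc(-c3ccccc3)cc(-c3ccco3)n2)c1`: 13500 nM

In a functional assay on HCT-15 cells (Homo sapiens) for cytotoxicity, read by ELISA, with a stated time of 2 days (a higher number here means a weaker inhibitor, a lower number a stronger inhibitor), compound 2 cannot be separated from the other two compounds: a 1.3-fold lower number from compound 1 to compound 2 (0.11 log units; within the scatter) and a 1.8-fold higher number from compound 2 to compound 3 (0.25 log units; within the scatter). Compound 4 `Oc1ccc(-c2cc(-c3ccccc3)cc(-c3ccsc3)n2)cc1` has the same atoms as compound 2, joined differently: 4-hydroxyphenyl in place of 3-hydroxyphenyl on an aromatic carbon. Among the compounds with values here, no measured step moves the hydroxyl group. The nearest evidence comes from changes at another substituent, a 1.4-fold higher number from compound 1 to compound 3 (0.13 log units; within the scatter) and the two steps above, and it bears only indirectly. No step beyond the scatter is therefore expected, although the range stays wide for this untested change. The estimated shift, a 1.0-fold higher number from compound 2 to compound 4 (0.02 log units; within the scatter), stays within the scatter. Compound 4 is estimated at 8000 nM, with an expected range of 3000 nM to 20000 nM.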

Compound 4, half-maximal inhibitory concentration: 1100 nM
Beside the measured number, compound 4's estimate is 7.3-fold (0.86 log units) above it; the measured number lies below the stated range.
By their numbers in this assay, from the lowest: compound 4; then compounds 2, 1 and 3 (each within the scatter of the next).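

In this assay, within the data shown here, the change from 3-hydroxyphenyl to 4-hydroxyphenyl gives a 7.0-fold lower number from compound 2 to compound 4 (0.84 log units; beyond the scatter), the only step beyond the scatter; the exchanges among phenyl, thiophen-3-yl and furan-2-yl all stay within it. The aromatic ring next to the ring nitrogen is therefore sensitive to where the hydroxyl sits, even with the atoms unchanged. Nothing available accounts for this step.

Open, as far as these compounds go, is whether 4-hydroxyphenyl gives a similar step alongside phenyl or furan-2-yl in place of thiophen-3-yl. Also open, from the compounds shown here alone, is whether an amine or a methoxy group can stand in for the hydroxyl.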